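A few compounds are considered here, and "the series" means these few. Any claim that something is new, unique, unknown or untested is made for them only; others in the source may bear on it.

Working notes on the series. The shared core of compound 1 `O=C(/C=C/c1cccc(Cl)c1Cl)Nc1cc2c(Nc3ccc(F)c(Cl)c3)ncnc2cc1O[C@H]1CCOC1` is kept throughout; in a functional assay on HeLa cells (Homo sapiens) for cytotoxicity, read by MTT assay, with a stated time of 72 h (a lower number here means a stronger inhibitor, a higher number a weaker inhibitor), compound 1 gives 30500 nM. Within the data shown here, compound 2 `COc1ccc(/C=C/C(=O)Nc2cc3c(Nc4ccc(F)c(Cl)c4)ncnc3cc2O[C@H]2CCOC2)c(OC)c1OC` holds the lowest of the two numbers so far: in this assay compound 2 gives 4830 nM, and the only measured step, a 6.3-fold lower number from compound 1 to compound 2 (0.80 log units; beyond the scatter), exchanges the dichlorophenyl for the trimethoxyphenyl and is beyond the scatter. Compound 3 `COc1cc2ncnc(Nc3ccc(F)c(Cl)c3)c2cc1NC(=O)/C=C/c1cc(OC)c(OC)c(OC)c1` carries the same trimethoxyphenyl on a different core, and in this assay compound 3 gives "not determined" (no result reported).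

The next step goes from compound 2 to compound 4 `O=C(/C=C/c1ccccc1[N+](=O)[O-])Nc1cc2c(Nc3ccc(F)c(Cl)c3)ncnc2cc1O[C@H]1CCOC1`. The change is 2-nitrophenyl in place of 2,3,4-trimethoxyphenyl on a double-bonded chain carbon bound to a double-bonded chain carbon. Among the measured compounds shown here, the one step that bears on it is the move from compound 1 to compound 2, where a halogenated aryl gave way to the trimethoxyphenyl and the number fell. The nitrophenyl of compound 4 is closer in kind to the dichlorophenyl of compound 1 than to the trimethoxyphenyl, so a step back toward the higher number of compound 1 is expected, though of uncertain size.

For compound 4 the expected step is a 3.1-fold higher number from compound 2 to compound 4 (0.49 log units; beyond the scatter). Compound 4 is estimated at 15000 nM, within a range of 5000 nM to 45000 nM.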

Compound 4, half-maximal inhibitory concentration: 29600 nM
Beside the measured number, compound 4's estimate is 2.0-fold (0.30 log units) below it; the range from low to high includes it.
By their numbers in this assay, from the lowest: compound 2; then compounds 4 and 1 (each within the scatter of the next).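

In this assay, the step with the 2-nitrophenyl on a double-bonded chain carbon bound to a double-bonded chain carbon is a 6.1-fold higher number from compound 2 to compound 4 (0.79 log units; beyond the scatter), so a second group in place of the 2,3,4-trimethoxyphenyl, this one without halogen, also goes with a higher number. The comparison of the two non-methoxy groups is a 1.0-fold lower number from compound 1 to compound 4 (0.01 log units; within the scatter), so 2-nitrophenyl and 2,3-dichlorophenyl cannot be told apart at this position, and among the three groups read here only the 2,3,4-trimethoxyphenyl stands apart. Nothing at hand accounts for either step.

Open, as far as these compounds go, is whether the number of compound 2 depends on all three methoxy groups or would hold with a single methoxy group on the phenyl. Also open, from the compounds shown here alone, is how an unsubstituted phenyl, or a phenyl carrying an amine or a carboxylic acid, would read at this position.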